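The source may report more compounds than this note shows. Statements on the series, on what has been measured and on what is new or still open speak of the compounds shown alone.

Measured so far in a functional assay on MCF7 cells (Homo sapiens) for cytotoxicity, read by MTT assay, with a stated time of 72 h; on this read-out lower numbers stand for stronger inhibition and higher numbers for weaker inhibition:

- compound 1 `CCCC[S+]([O-])CCCCN=C=S`: 5840 nM
- compound 2 `CC(C)[S+]([O-])CCCCN=C=S`: 8820 nM
- compound 3 `[O-][S+](CCCCN=C=S)CCc1ccccc1`: 9330 nM

Compound 1 has the lowest of these three numbers, but that position means little, since the other two both lie within the usual scatter of it. The next compound, compound 4 `[O-][S+](CCCCN=C=S)Cc1ccco1`, departs from compound 1 in one place: furan-2-yl in place of propyl on a saturated chain carbon bound to a sulfur. In words, furan-2-yl stands in place of propyl on a saturated chain carbon bound to a sulfur.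

For the measured compounds named here, only one measured step changes the group on the sulfur directly: a 1.5-fold higher number from compound 1 to compound 2 (0.18 log units; within the scatter). It replaces one open chain with another, so it bears on the new change only loosely, and it stays within the scatter. Compound 3 is the closer guide, as it also carries a ring. Compound 3 gives 9330 nM, which is still within the scatter of compound 1. So far, then, nothing has moved this read-out beyond the scatter, and no such move is expected in this assay for compound 4, though no furan has been measured yet. The estimated step is a 1.3-fold higher number from compound 1 to compound 4 (0.11 log units; within the scatter). For compound 4 the expected value is 7500 nM. The expected range for compound 4 runs from 3500 nM to 15000 nM.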

Compound 4, half-maximal inhibitory concentration: 5680 nM
Compound 4: the middle estimate sits 1.3-fold (0.12 log units) above what was measured, within the range that was stated.
By their numbers in this assay, from the lowest: compounds 4, 1, 2 and 3 (each within the scatter of the next).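

In this assay the step of a 1.0-fold lower number from compound 1 to compound 4 (0.01 log units; within the scatter) comes from putting furan-2-yl in place of propyl on a saturated chain carbon bound to a sulfur. This step shows that an open propyl chain at this position can give way to a five-membered aromatic ring with a hetero atom and a hydrogen-bond acceptor, and the read-out still does not move beyond the usual scatter of repeated measurements. No measurement on hand says why the number holds here, so this stays a plain observation about one exchange on the core of compound 1.

Still open is whether any group at this position can shift cytotoxicity on these cells by more than the scatter, as no step shown so far does so. An amine, a carboxylic acid or a longer chain in this place would test that, and a six-membered ring such as pyridine would show whether the tolerance seen with furan-2-yl extends to other rings.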